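The source may report more compounds than this note shows. Statements on the series, on what has been measured and on what is new or still open speak of the compounds shown alone.

Three stilbenes have been tested in an assay on HepG2 cells for activation of nuclear factor erythroid 2-related factor 2 (Homo sapiens), read by a luciferase reporter, with a stated time of 5 h; on this read-out lower numbers stand for an effect already at smaller amounts and higher numbers for an effect only at larger amounts of compound. Compound 1 `Fc1ccccc1/C=C/c1ccccc1` gives 700 nM, compound 2 `Fc1cccc(/C=C/c2ccccc2)c1` gives 3100 nM, and compound 3 `COc1ccc(/C=C/c2ccc(F)cc2)cc1` gives 4200 nM. Compound 3 thus sits at the upper end of the three numbers; its gap to compound 2 lies within the usual scatter, whereas compound 1 stands clearly apart with a smaller number. Compound 4 `Cc1ccc(/C=C/c2ccc(F)cc2)cc1` has not yet been measured. It differs from compound 3 by methyl in place of methoxy on an aromatic carbon. For the measured compounds named here, no measured pair shows the effect of swapping these two groups, so the expectation rests on the small size of the change alone: the step from compound 3 to compound 4 is expected to be a 1.2-fold lower number from compound 3 to compound 4 (0.08 log units; within the scatter), within the scatter. Compound 4 is therefore estimated at 3500 nM, between 1500 nM and 9000 nM.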

Compound 4, half-maximal effective concentration: 1300 nM
Beside the measured number, compound 4's estimate is 2.7-fold (0.43 log units) above it; measured number below the stated range.
By their numbers in this assay, from the lowest: compounds 1 and 4 (each within the scatter of the next); then compounds 2 and 3 (each within the scatter of the next).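

In this assay the position on the aromatic carbon responds to even a small swap: methyl in place of methoxy gives a 3.2-fold lower number from compound 3 to compound 4 (0.51 log units; beyond the scatter) and this modest step lies beyond the scatter. For the compounds shown here, it is also the first direct comparison of compounds that differ in only one place, so a single change can now be read on its own. Nothing available explains why the number falls with this swap. Still open, on these data alone, is how an amine, a hydroxyl group or a longer chain such as ethyl would fare at this position. Also open, as far as these compounds go, is whether the same swap would give a similar step with the fluorine elsewhere on the other ring.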